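A few compounds are considered here, and "the series" means these few. Any claim that something is new, unique, unknown or untested is made for them only; others in the source may bear on it.

Of the compounds shown here, three built on one shared core have been measured. Compound 1 `COc1ccc(C(=O)/C=C/c2cc(-c3cc(OC)c(OC)c(OC)c3)n3nc(-c4ccccc4)cc3n2)cc1OC` gives 17800 nM in a functional assay on A549 cells (Homo sapiens) for antiproliferative activity, read by MTT assay, with a stated time of 24 h (a higher number here means a weaker inhibitor, a lower number a stronger inhibitor), compound 2 `COc1ccc(-c2cc(/C=C/C(=O)c3ccc(OC)c(OC)c3)nc3cc(-c4ccccc4)nn23)cc1` gives 7400 nM there, and compound 3 `COc1ccc(C(=O)/C=C/c2cc(-c3ccc(OC)c(OC)c3)n3nc(-c4ccccc4)cc3n2)cc1` gives 11900 nM, the second highest of the three numbers; its gaps to compound 1 and to compound 2 both lie within the scatter. Among the compounds with values here, the only single-point step measured so far is a 2.4-fold lower number from compound 1 to compound 2 (0.38 log units; beyond the scatter). Compound 4 `COc1ccc(-c2cc(C(=O)/C=C/c3ccccc3)nc3cc(-c4ccccc4)nn23)cc1OC` differs from compound 3 by (2-phenylethenyl)carbonyl in place of 2-((4-methoxyphenyl)carbonyl)ethenyl on an aromatic carbon. Within the data shown here, no measured step bears on this change: the one step at hand alters the 3,4,5-trimethoxyphenyl group, not the chain exchanged here. The analyst therefore expects a 1.2-fold higher number from compound 3 to compound 4 (0.07 log units; within the scatter) to stay within the scatter, in no firm direction. For compound 4 the estimate is 14000 nM, between 5000 nM and 40000 nM.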

Compound 4, half-maximal inhibitory concentration: 18600 nM
Compound 4: the middle estimate sits 1.3-fold (0.12 log units) below what was measured, and the stated range covers the measured number.
By their numbers in this assay, from the lowest: compounds 2, 3, 1 and 4 (each within the scatter of the next, the first and the last beyond it).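

In this assay, 2-((4-methoxyphenyl)carbonyl)ethenyl gives way to (2-phenylethenyl)carbonyl on the aromatic carbon next to the ring nitrogen, with a 1.6-fold higher number from compound 3 to compound 4 (0.19 log units; within the scatter). Within the data shown here, this is the first reading at this position, and it shows that this exchange of one aryl-bearing chain for another produces no change beyond the scatter. No available evidence accounts for this result. The compounds shown leave open whether an amine or a carboxylic acid in place of the whole chain would move the number beyond the scatter. They also leave apart the loss of the methoxy group and the shift of the carbonyl to the ring side of the chain, as the two change together in this step.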